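3-chlorobenzyl to 2-chlorobenzyl: notes on compound 4

The compounds below may be only part of what the source reports. "The series", "measured", "known", "first", "only" and "open" are said of these compounds alone.

Of the compounds shown here, three have been read in a functional assay on MDA-MB-231 cells (Homo sapiens) for cytotoxicity, read by MTT assay, with a stated time of 24 h; on this read-out lower numbers stand for stronger inhibition and higher numbers for weaker inhibition. Compound 1 (`COc1ccc(/C=C2\CN(C(=S)SCc3cn(Cc4ccccc4F)nn3)C/C(=C\c3ccc(OC)cc3)C2=O)cc1`) gives > 100000 nM, which is a limit of the assay and not a number. Compound 2 (`COc1ccc(/C=C2\CN(Cc3cn(Cc4cccc(Cl)c4)nn3)C/C(=C\c3ccc(OC)cc3)C2=O)cc1`) gives 98000 nM, and compound 3 (`Cc1ccc(/C=C2\CN(Cc3cn(Cc4ccc(F)cc4)nn3)C/C(=C\c3ccc(C)cc3)C2=O)cc1`) gives 26800 nM. Compound 2 therefore holds the higher of the two actual numbers, and its gap to compound 3 lies beyond the scatter.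

Compound 4 (`COc1ccc(/C=C2\CN(Cc3cn(Cc4ccccc4Cl)nn3)C/C(=C\c3ccc(OC)cc3)C2=O)cc1`) has not yet been measured. Its change from compound 2 is 2-chlorophenyl in place of 3-chlorophenyl on a saturated chain carbon bound to an aromatic nitrogen, with the same atoms joined differently. For the measured compounds named here, the series holds no measured step between compounds that differ in one place, so the expectation rests on the value of compound 2 and on this change alone.

The expected step of a 1.4-fold lower number from compound 2 to compound 4 (0.15 log units; within the scatter) in this assay is estimated to stay within the scatter, with a slightly lower number more likely than a higher one. Compound 2 stands at 98000 nM, with little room left before readings stop being numbers. A report of compound 4 only as a limit therefore remains possible. For compound 4 the expected value is 70000 nM, with an estimated range of 25000 nM to 100000 nM.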

Compound 4, half-maximal inhibitory concentration: > 100000 nM
Compound 4: no number, only a limit; the forecaster's own chance of this, stated with the estimate: 25%; at least 1.4-fold (0.15 log units) between middle value and limit.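

Compound 4 gives > 100000 nM in this assay, which is a limit of the assay and not a number. For the compounds shown here, this is the first one-place change: 2-chlorobenzyl in place of 3-chlorobenzyl, on a saturated chain carbon bound to an aromatic nitrogen, with the same atoms joined differently, gives an at least 1.0-fold higher number from compound 2 to compound 4 (0.00 log units; that floor lies within the scatter), so on the shared core of compound 2 this change brings no reading that can be told from the parent, and it shows no gain in inhibition. The step has a floor but no upper end, and its true size cannot be read, because the reading of compound 4 stops at the limit of the assay: the limit of > 100000 nM in this assay, at which 2 of the 4 values shown sit.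

Compound 3, at 26800 nM, differs from compound 2 in more than one place, so the compounds shown do not say which of those differences goes with its lower number. Also open, on these data alone, is whether a 4-chlorobenzyl group, or a benzyl group carrying an amine or a carboxylic acid, would bring the core of compound 2 clear of the limit.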